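A few compounds are considered here, and "the series" means these few. Any claim that something is new, unique, unknown or untested is made for them only; others in the source may bear on it.

Compound 1 `N#Cc1ccc2c(Oc3ccc(Cl)cc3OCCn3ccc(=O)[nH]c3=O)cccc2c1` and compound 3 `N#Cc1ccc2c(Oc3ccc(F)cc3OCCn3ccc(=O)[nH]c3=O)cccc2c1` share one core, while compound 2 `N#Cc1cc2c(Oc3ccc(F)cc3OCCn3ccc(=O)[nH]c3=O)cc(F)cn2c1` carries another; the difference between the two cores is not broken down here. In an ADME assay on MT2 cells (Homo sapiens) for cytotoxicity, read by MTT assay (on this read-out lower numbers stand for higher toxicity in this test and higher numbers for lower toxicity in this test), compound 3 reaches only the assay limit, > 100000 nM. Compound 1 likewise gives a limit, > 100000 nM. The step that the two limits leave unreadable from compound 3 to compound 1 thus stays unreadable; the change is chloro in place of fluoro on an aromatic carbon. Among the compounds with values here, compound 2 is the only one with a number, giving 50000 nM in this assay. Compound 4 `N#Cc1cc2c(Oc3ccc(F)cc3OCCn3ccc(=O)[nH]c3=O)cc(Cl)cn2c1` arises from compound 2 by the same kind of change, (chloro in place of fluoro on an aromatic carbon), here on a six-membered aromatic ring with one nitrogen, part of a fused or bridged system of two rings, rather than a ring of carbon only. Because (the limit of > 100000 nM in this assay, at which 2 of the 3 values shown sit), the earlier step offers no size to lean on. For compound 4 the expected step is no change at the digits printed from compound 2 to compound 4 (within the scatter), since compound 2 gives 50000 nM and the matching step is unreadable. Compound 4 is therefore estimated at 50000 nM, between 20000 nM and 100000 nM.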

Compound 4, half-maximal cytotoxic concentration: 15000 nM
Compound 4: the middle estimate sits 3.3-fold (0.52 log units) above what was measured, outside the stated range (below it).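

In this assay, chloro in place of fluoro on an aromatic carbon of the six-membered aromatic ring with 1 nitrogen gives a 3.3-fold lower number from compound 2 to compound 4 (0.52 log units; beyond the scatter), toward higher toxicity in this test. The same change from compound 3 to compound 1 cannot be read, because both compounds sit at a limit of the assay: the limit of > 100000 nM in this assay, at which 2 of the 4 values shown sit. The step therefore shows what the change does on the core of compound 2, but not whether it carries over to the core of compound 1, and one readable pair sets no rule for the series.

The compounds shown leave open how other groups on that same aromatic carbon, such as a methyl, a methoxy or an amine, would read. They also leave open whether replacing the nitrile would alter the step.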